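Chloro added to the core of compound 2

The compounds below may be only part of what the source reports. "The series", "measured", "known", "first", "only" and "open" are said of these compounds alone.

Measured so far:
compound 1 `O[C@@H]1Cc2cc(Cl)ccc2N[C@H](c2ccccc2F)C1` — 182000 nM
compound 2 `O[C@@H]1Cc2ccccc2N[C@H](c2c(F)cccc2Cl)C1` — its value is a limit only, > 300000 nM

In an ADME assay on Vero cells (Chlorocebus sabaeus) for cytotoxicity, read by MTT assay, with a stated time of 72 h (on this read-out lower numbers stand for higher toxicity in this test and higher numbers for lower toxicity in this test), compound 1 gives 182000 nM. Compound 2 gives no number in this assay, only > 300000 nM, which is the limit of > 300000 nM in this assay, at which 1 of the 2 values shown sits. So compound 2 stands at the upper edge of what the assay reports, and its place relative to compound 1 cannot be fixed more closely than that. Within the data shown here, no pair of measured compounds differs in a single place, so no measured step is available.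

Compound 3 `O[C@@H]1Cc2cc(Cl)ccc2N[C@H](c2c(F)cccc2Cl)C1` is compound 2 with chloro in place of hydrogen on an aromatic carbon. The same chloro on the core is carried by compound 1, whose value sits below the limit. On that basis the step in this assay is expected to be small, downward if anything, or none beyond the usual scatter, and a second limit read-out remains a real possibility. For compound 3 the expected value is 200000 nM, with a range of 100000 nM to 400000 nM, a step of an at least 1.5-fold lower number from compound 2 to compound 3 (0.17 log units; that floor lies within the scatter).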

Compound 3, half-maximal cytotoxic concentration: 92000 nM
The estimate for compound 3 lay 2.2-fold (0.34 log units) above the measured number; measured number below the stated range.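

In this assay, chloro in place of hydrogen on an aromatic carbon of the fused two-ring system gives an at least 3.2-fold lower number from compound 2 to compound 3 (0.51 log units; beyond the scatter), so a change at this position of the shared core can be read beyond the scatter in this test. The size of that step is a floor only, as the value for compound 2 is a limit and not a number: the limit of > 300000 nM in this assay, at which 1 of the 3 values shown sits. The other single change that reaches compound 3, chloro in place of hydrogen on an aromatic carbon outside the core position, gives a 2.0-fold lower number from compound 1 to compound 3 (0.30 log units; within the scatter), and this step stays within the scatter.

The compounds shown leave open whether another group on the same carbon, such as fluoro, methoxy or an amine, would give a step like that of chloro. They also leave open how large the core chloro step is when the other aromatic ring carries only the fluoro of compound 1, and how far the step from compound 2 really extends beyond its floor.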